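Aryl swap on the saturated ring carbon: estimating compound 4

The source may report more compounds than this note shows. Statements on the series, on what has been measured and on what is new or still open speak of the compounds shown alone.

Measured so far:
compound 1, `O=C(C(Nc1ccccc1)c1ccc(C(F)(F)F)cc1)N1CCC[C@H]1c1ccccc1Cl`, gives 41 nM in an assay on HEK293 cells for antagonist activity at transient receptor potential M8 protein (Canis lupus familiaris), read by fluorescence and calcium flux, with a stated time of 5 min; on this read-out lower numbers stand for stronger inhibition and higher numbers for weaker inhibition.
compound 2, `O=C(C(Nc1ccccc1)c1ccc(C(F)(F)F)cc1)N1CCC[C@@H]1c1ccccc1Cl`, gives 168 nM.
compound 3, `O=C(C(Nc1ccccc1F)c1ccc(C(F)(F)F)cc1)N1CCCC1c1cccc(F)c1`, gives 9 nM.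

Compound 3 holds the lowest of the three numbers; compound 1 sits higher, and compound 2 higher still, both gaps beyond the scatter. Compound 4, `O=C(C(Nc1ccccc1F)c1ccc(C(F)(F)F)cc1)N1CCCC1c1ccccc1Cl`, differs from compound 3 by 2-chlorophenyl in place of 3-fluorophenyl on a saturated ring carbon. Within the data shown here, the only measured step, a 4.1-fold higher number from compound 1 to compound 2 (0.61 log units; beyond the scatter), concerns the drawn configuration at the saturated ring carbon and not the group it carries, so no measured step bears directly on this swap. Compounds 1 and 2 already carry 2-chlorophenyl on that carbon, with an unsubstituted anilino group, and both give higher numbers than compound 3, which carries 3-fluorophenyl with a 2-fluoroanilino group; the two changes cannot be separated from the numbers shown. Compound 4 keeps the 2-fluoroanilino group of compound 3 and takes the 2-chlorophenyl of compounds 1 and 2, and is therefore expected to land between compound 3 and compound 1, a modest rise of a 2.4-fold higher number from compound 3 to compound 4 (0.39 log units; beyond the scatter). The estimate for compound 4 in this assay is 22 nM, with a range from 7 nM to 70 nM.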

Compound 4, half-maximal inhibitory concentration: 11 nM
The estimate for compound 4 lay 2.0-fold (0.30 log units) above the measured number; measured number inside the range.
By their numbers in this assay, from the lowest: compounds 3 and 4 (each within the scatter of the next); then compound 1; then compound 2.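

With the 2-fluoroanilino group held constant, the swap on the saturated ring carbon next to the ring nitrogen gives a 1.2-fold higher number from compound 3 to compound 4 (0.09 log units; within the scatter) in this assay, so the numbers do not separate 2-chlorophenyl from 3-fluorophenyl at this position. Among these compounds, this is the first step that concerns the aryl group on that carbon, as the only earlier step, a 4.1-fold higher number from compound 1 to compound 2 (0.61 log units; beyond the scatter), concerns the drawn configuration there. Nothing at hand offers a cause for the new step, and the available note on the drawn configuration of compounds 1 and 2 does not bear on this swap.

Compound 3 and compound 4 are drawn without a configuration at the saturated ring carbon, so the shown compounds leave open how each separate configuration reads with the 2-fluoroanilino group present. Also open is how this assay would respond to a pyridyl ring, a carboxylic acid-bearing phenyl group or a longer alkyl chain on that carbon in place of the two aryl groups shown.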